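The source may hold more compounds than are shown below. What is called first, only, known or untested is meant among the compounds shown, and "the series" means these compounds.

Compound 1 `CCc1cnc(N2CCC(n3ncc4cc(-c5ccc(S(C)(=O)=O)cc5)ccc43)CC2)nc1` — < 110 nM in a physicochemical assay for solubility, read by HPLC, in phosphate buffer, measured as thermodynamic solubility, with a stated time of 24 h, at pH 6.8 (on this read-out lower numbers stand for lower solubility and higher numbers for higher solubility), a limit of that assay rather than a number.
Compound 2 `CCc1cnc(N2CCC(n3nnc4cc(-c5ccc(S(C)(=O)=O)cc5)ncc43)CC2)nc1` — 280 nM in this assay.
Compound 3 `CCNC(=O)c1ccc(-c2cc3nnn(C4CCN(c5ncc(CC)cn5)CC4)c3cn2)cc1C` — 1790 nM in this assay.

Compound 3 holds the highest of the two numbers shown in this assay; the nearest, compound 2, sits beyond the scatter from it, and compound 1 contributes only a limit (the limit of < 110 nM in this assay, at which 1 of the 3 values shown sits). Compound 4 `CCNC(=O)c1ccc(-c2cc3nnn(C4CCN(c5ncc(CC)cn5)CC4)c3cn2)cc1Cl` differs from compound 3 by chloro in place of methyl on an aromatic carbon. Among the measured compounds shown here, no measured pair shows this change, so its size is unknown from the data. The step is expected to be small and within the scatter, a 1.5-fold lower number from compound 3 to compound 4 (0.17 log units; within the scatter). Compound 4 is estimated at 1200 nM in this assay, with a range from 400 nM to 3500 nM.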

Compound 4, solubility: < 160 nM
Compound 4 ended at the assay's limit; the forecaster's own chance of this, stated with the estimate: 5%; middle value at least 7.5-fold (0.87 log units) from the limit.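

In this assay, chloro in place of methyl on this aromatic carbon, ortho to an ethylcarbamoyl group, gives an at least 11-fold lower number from compound 3 to compound 4 (1.04 log units; beyond the scatter). Among the compounds shown here, this exchange of one heavy atom for one is the first measured single-place change, and it shows that this position can move the read-out well beyond the scatter. The value of compound 4 is a limit and not a number: the limit of < 160 nM in this assay, at which 1 of the 4 values shown sits.

From the compounds shown here alone, its true value therefore stays open, and so does the full size of the step. Also open, going by these compounds, is how fluoro, methoxy or a nitrile would read on this carbon.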